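Nitro-to-amino exchange carried from one core to another

This account rests on a few compounds, and the source may have more. Where it says the series, first, only, none or still open, it means among the compounds named here.

Measured compounds:
compound 1 `COc1ccc(CS(=O)(=O)/C=C/c2c(OC)cc(O)cc2OC)cc1[N+](=O)[O-]`: 5000 nM
compound 2 `COc1ccc(CS(=O)(=O)/C=C/c2c(OC)cc(O)cc2OC)cc1N`: 200 nM
compound 3 `COc1cc(OC)c(/C=C/SCc2ccc(OC)c([N+](=O)[O-])c2)c(OC)c1`: 5000 nM

In a functional assay on DU-145 cells (Homo sapiens) for cytotoxicity, read by trypan blue exclusion, with a stated time of 96 h (on this read-out lower numbers stand for stronger inhibition and higher numbers for weaker inhibition), compound 1 gives 5000 nM. Compound 2 gives 200 nM, and compound 3 gives 5000 nM.

Compound 1 and compound 2 differ in one place: amino in place of nitro on an aromatic carbon. For the measured compounds named here, this gives a 25-fold lower number from compound 1 to compound 2 (1.40 log units; beyond the scatter), the one large step among the three measured compounds. Compound 3 stands level with compound 1 at the digits given, within the usual scatter of this assay; the difference between the two cores is not broken down here.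

Compound 4 `COc1cc(OC)c(/C=C/SCc2ccc(OC)c(N)c2)c(OC)c1` has not yet been measured in this assay. It differs from compound 3 by amino in place of nitro on an aromatic carbon. Going by the values given here, this is the same change as the one from compound 1 to compound 2, and the words describing its place are the same. Among the compounds shown, this change occurs twice in all, once measured and once open.

The step from compound 3 to compound 4 is expected to be a 17-fold lower number from compound 3 to compound 4 (1.22 log units; beyond the scatter) in this assay, a step of about the same size as the measured one, because a 25-fold lower number from compound 1 to compound 2 (1.40 log units; beyond the scatter) and compound 3 gives 5000 nM, the same starting level as compound 1. A single example of the change on one core is a thin basis, so the range is kept wide. Compound 4 is expected at 300 nM in this assay, with a range from 100 nM to 1500 nM.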

Compound 4, half-maximal inhibitory concentration: 50 nM
Compound 4: middle estimate off by 6.0-fold (0.78 log units), on the high side; the whole stated range lies above it.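

In this assay amino in place of nitro lowers the number on the second core as it did on the first, giving a 100-fold lower number from compound 3 to compound 4 (2.00 log units; beyond the scatter). The direction therefore carries from one core to the other, but the size does not carry over unchanged: the same change on two cores in this assay, a 25-fold lower number (1.40 log units; beyond the scatter) from compound 1 to compound 2 and a 100-fold lower number (2.00 log units; beyond the scatter) from compound 3 to compound 4, 4.0-fold (0.60 log units) apart, beyond the scatter of two such steps. These two pairs do not show where the gap between the steps comes from: the core of compound 1 and the core of compound 3 differ in more than one place, including the oxidation state of the sulfur linker and a hydroxy against a methoxy on the ring, and no pair shown separates these differences, nor do two pairs predict the size of the step on a third core.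

Still open, as far as these compounds go, is which of those differences between the cores goes with the larger step, a question that compounds changing only the sulfur linker or only the hydroxy would address. Also open, from the compounds shown here alone, is whether the low number of compound 4 at 50 nM is specific to amino or is kept with an acetamide or a dimethylamino group on the same aromatic carbon.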